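Swapping Piperidine for Cyclopentylamino in a Cytotoxic Series

This account rests on a few compounds, and the source may have more. Where it says the series, first, only, none or still open, it means among the compounds named here.

Of the compounds shown here, two sharing a long unsaturated chain have been measured in a functional assay on MIA PaCa-2 cells (Homo sapiens) for cytotoxicity, read by fluorescence, with a stated time of 48 h; a higher number here means that more compound is needed for the effect, a lower number that less compound is needed. There, compound 1 `CC(C)=CCC/C(C)=C/CC/C(C)=C/CSC[C@H](NC(=O)CCCCCN1CCCC1)C(=O)NC1CCCC1` gives 3200 nM. Compound 2 `CC(C)=CCC/C(C)=C/CC/C(C)=C/CSC[C@H](NC(=O)CCCCCN1CCN(C)CC1)C(=O)N1CCCCC1` gives 14300 nM, the higher of the two numbers, and its gap to compound 1 lies beyond the usual scatter. Compound 3 `CC(C)=CCC/C(C)=C/CC/C(C)=C/CSC[C@H](NC(=O)CCCCCN1CCN(C)CC1)C(=O)NC1CCCC1` has not yet been measured. It arises from compound 2 by one change, with cyclopentylamino in place of piperidin-1-yl on a carbonyl carbon. For the measured compounds named here, no measured pair isolates this change, so any forecast is uncertain. The nearest guide is compound 1, which also carries cyclopentylamino on that carbonyl carbon and gives 3200 nM. It differs from compound 3 elsewhere, however, so it offers only a loose indication. A moderate fall in the number is therefore expected, one that may not clear the scatter, and the estimated step is a 2.2-fold lower number from compound 2 to compound 3 (0.34 log units; beyond the scatter). The estimate for compound 3 is 6500 nM, with an expected range of 2500 nM to 15000 nM.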

Compound 3, half-maximal effective concentration: 10900 nM
Compound 3: middle estimate off by 1.7-fold (0.22 log units), on the low side; the measured number falls inside the stated range.
By their numbers in this assay, from the lowest: compound 1; then compounds 3 and 2 (each within the scatter of the next).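

In this assay, the piperidin-1-yl and cyclopentylamino amides prove indistinguishable on this background: cyclopentylamino in place of piperidin-1-yl on a carbonyl carbon gives a 1.3-fold lower number from compound 2 to compound 3 (0.12 log units; within the scatter), so adding a hydrogen-bond donor at this position leaves the read-out within the usual scatter when 4-methylpiperazin-1-yl sits on the chain. The other single change does register, since 4-methylpiperazin-1-yl in place of pyrrolidin-1-yl on a saturated chain carbon, five bonds along the chain from a carbonyl carbon, gives a 3.4-fold higher number from compound 1 to compound 3 (0.53 log units; beyond the scatter), a modest step beyond the scatter, and among these compounds it is the chain-end group rather than the carbonyl substituent that shifts the number. No measured data accompany these steps that could explain either of them.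

Whether the carbonyl exchange would stay as small with pyrrolidin-1-yl on the chain remains open, as the piperidin-1-yl amide is shown only with 4-methylpiperazin-1-yl. As far as these compounds go, it is also open how a morpholin-4-yl group at the carbonyl carbon, or a dimethylamino group at the end of the chain, would read in this assay on the same shared core.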